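A few compounds are considered here, and "the series" means these few. Any claim that something is new, unique, unknown or untested is made for them only; others in the source may bear on it.

The measured compounds, in a functional assay on HeLa cells (Homo sapiens) for cytotoxicity, read by MTT assay, with a stated time of 48 h; a lower number here means a stronger inhibitor, a higher number a weaker inhibitor:

Compound 1, `Cc1ccc(Cn2cc(COc3ccc4c(=O)ccoc4c3)nn2)cc1`, gives only a limit in this assay, > 100000 nM.
Compound 2, `Cc1ccccc1Cn1cc(COc2ccc3c(=O)ccoc3c2)nn1`, gives 15300 nM.
Compound 3, `O=c1ccoc2cc(OCc3cn(Cc4ccc(F)cc4)nn3)ccc12`, gives 12000 nM.

Among the two numbers shown, compound 3 holds the lower one, but its nearest neighbour, compound 2, sits within the scatter of it: a 1.3-fold lower number from compound 2 to compound 3 (0.11 log units; within the scatter). The third value, that of compound 1, is a limit of this assay, (the limit of > 100000 nM in this assay, at which 1 of the 3 values shown sits), so only a bound is known there.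

Compound 4, `O=c1ccoc2cc(OCc3cn(Cc4cccc(Cl)c4)nn3)ccc12`, is the next step from compound 3: 3-chlorophenyl in place of 4-fluorophenyl on a saturated chain carbon bound to an aromatic nitrogen. For the measured compounds named here, no measured pair covers a chloro group, nor a substituent in this ring position. The steps that come nearest are those that move or exchange the single ring substituent on the benzyl group: an at least 6.5-fold lower number from compound 1 to compound 2 (0.81 log units; beyond the scatter) and an at least 8.3-fold lower number from compound 1 to compound 3 (0.92 log units; beyond the scatter), both starting from a limit, and a 1.3-fold lower number from compound 2 to compound 3 (0.11 log units; within the scatter), which shows that exchanging one such substituted phenyl for another can leave the number where it was. Going by the values given here, with no step that distinguishes chloro from fluoro, the expected change from compound 3 to compound 4 in this assay is none beyond the scatter, no change at the digits printed from compound 3 to compound 4 (within the scatter). Compound 4 is therefore estimated at 12000 nM, with a range from 4000 nM to 40000 nM.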

Compound 4, half-maximal inhibitory concentration: > 100000 nM
Compound 4: no number, only a limit (the forecaster's own chance of this, stated with the estimate: 15%); at least 8.3-fold (0.92 log units) between middle value and limit.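

In this assay compound 4 gives > 100000 nM, which is a limit and not a number. The exchange of 4-fluorophenyl for 3-chlorophenyl gives an at least 8.3-fold higher number from compound 3 to compound 4 (0.92 log units; beyond the scatter), and that of 2-methylphenyl for 3-chlorophenyl gives an at least 6.5-fold higher number from compound 2 to compound 4 (0.81 log units; beyond the scatter), so the substituted phenyl on this saturated chain carbon bound to an aromatic nitrogen can be exchanged with a clear effect on the read-out, which the earlier pair with two numbers, a 1.3-fold lower number from compound 2 to compound 3 (0.11 log units; within the scatter), did not show. Compound 1 and compound 4 now share this outcome, the step between them cannot be read, and the series divides into two compounds with numbers, compound 2 and compound 3, and two without: the limit of > 100000 nM in this assay, at which 2 of the 4 values shown sit.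

Compound 4 changes both the halogen and its place on the ring in a single step, so the compounds shown do not tell which of the two goes with the limit. Also open, on these data alone, is how an unsubstituted benzyl group, or a phenyl carrying a methoxy group or an amine at this place, would read in this assay.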